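The compounds below may be only part of what the source reports. "The series", "measured", "known", "first", "only" and "open" are said of these compounds alone.

Compound 1 `COc1ccc(C(=O)Nc2c(F)cccc2F)cc1OC1CCCC1`: 70 nM
Compound 2 `CCCCOc1cc(C(=O)Nc2c(F)cccc2F)ccc1OC`: 300 nM
Compound 3 `COc1ccc(C(=O)Nc2c(F)cccc2F)cc1OC1CCCCC1`: 400 nM

In an assay on isolated protein for inhibition of phosphodiesterase 4A (Sus scrofa) (on this read-out higher numbers stand for weaker inhibition and lower numbers for stronger inhibition), compound 1 gives the lowest number of the three. Its nearest neighbour is compound 2, a 4.3-fold higher number from compound 1 to compound 2 (0.63 log units; beyond the scatter); the furthest is compound 3, a 5.7-fold higher number from compound 1 to compound 3 (0.76 log units; beyond the scatter). Between the other two the gap is small, a 1.3-fold higher number from compound 2 to compound 3 (0.12 log units; within the scatter). All three of these steps alter the group on an oxygen on an aromatic ring and leave the amide-type nitrogen untouched.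

Compound 4 `COc1ccc(C(=O)NC2(C)C=C(C)ON2)cc1OC1CCCC1` differs from compound 1 elsewhere: a group of 7 heavy atoms (5 carbon, 1 nitrogen, 1 oxygen; one five-membered non-aromatic ring with 2 hetero atoms) in place of a group of 8 heavy atoms (6 carbon, 2 fluorine; one six-membered aromatic ring of carbon only), on an amide-type nitrogen. Within the data shown here, no measured step touches that side of the shared core, so none of the three steps bears directly on this change; the ring that leaves is the one part held constant across compound 1, compound 2 and compound 3. Because compound 1 sits at 70 nM, the lowest point of the set, and the change removes a ring carried by every measured compound, a weaker result is expected rather than a stronger one. Compound 4 is therefore estimated at 500 nM in this assay, within 100 nM to 3000 nM, which would mean an expected step of a 7.1-fold higher number from compound 1 to compound 4 (0.85 log units; beyond the scatter).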

Compound 4, half-maximal inhibitory concentration: 450 nM
Beside the measured number, compound 4's estimate is 1.1-fold (0.05 log units) above it; measured number inside the range.
By their numbers in this assay, from the lowest: compound 1; then compounds 2, 3 and 4 (each within the scatter of the next).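

In this assay, the amide-type nitrogen now has a measured change of its own: 2,6-difluorophenyl gives way to the five-membered non-aromatic ring, with a 6.4-fold higher number from compound 1 to compound 4 (0.81 log units; beyond the scatter). The group on this nitrogen therefore matters to the read-out even with the cyclopentyl group on the oxygen held constant, yet this single step swaps the aromatic ring, the fluorines and the hydrogen-bond donor and acceptor counts all at once and cannot separate them. Nothing available explains the size of this step.

Open, going by these compounds, is how a plain phenyl, a pyridine or a 2,6-dichlorophenyl group would read on this nitrogen, which would help separate those features. Also open, on these data alone, is whether butyl or cyclohexyl on the oxygen would give the same steps with the new ring in place.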